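Extending the benzyl group of compound 2 with a trifluoromethylpyridine

A few compounds are considered here, and "the series" means these few. Any claim that something is new, unique, unknown or untested is made for them only; others in the source may bear on it.

Of the compounds shown here, three of one core have been measured so far. Compound 1 `FC(F)(F)c1ccccc1-c1nc(NCc2ccccc2)c2ccccc2n1` gives 3100 nM in an assay on a protein complex for inhibition of ubiquitin carboxyl-terminal hydrolase 1/WD repeat-containing protein 48 (Homo sapiens), read by fluorescence; a higher number here means a weaker inhibitor, a lower number a stronger inhibitor. Compound 2 `COc1ccc(CNc2nc(-c3ccccc3C(F)(F)F)nc3ccccc23)cc1` gives 6200 nM, and compound 3 `FC(F)(F)c1ccccc1-c1nc(NCc2ccc(Cl)cc2)c2ccccc2n1` gives 4800 nM. Compound 2 carries the highest of the three numbers, but the gaps are small: a 2.0-fold higher number from compound 1 to compound 2 (0.30 log units; within the scatter) and a 1.3-fold lower number from compound 2 to compound 3 (0.11 log units; within the scatter), and likewise a 1.5-fold higher number from compound 1 to compound 3 (0.19 log units; within the scatter). The three substituents at this aromatic carbon therefore give indistinguishable results.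

Compound 4 `FC(F)(F)c1cc(-c2ccc(CNc3nc(-c4ccccc4C(F)(F)F)nc4ccccc34)cc2)ccn1` changes the same position: 2-(trifluoromethyl)pyridin-4-yl in place of methoxy on an aromatic carbon. The measured steps bear on it only loosely, since hydrogen, methoxy and chloro are all small, while the entering group adds a whole second aromatic ring. Those steps show that this position tolerates variation without loss, but nothing measured here tells how a much larger group behaves. The expected step is a 3.1-fold lower number from compound 2 to compound 4 (0.49 log units; beyond the scatter), with a wide range because the guidance rests on within-scatter steps alone. Compound 4 is therefore estimated at 2000 nM, between 300 nM and 12000 nM.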

Compound 4, half-maximal inhibitory concentration: 4900 nM
For compound 4 the middle estimate is 2.5-fold (0.39 log units) below the measured one, and the stated range covers the measured number.
By their numbers in this assay, from the lowest: compounds 1, 3, 4 and 2 (each within the scatter of the next).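

A whole second aromatic ring is accepted at this aromatic carbon: in this assay the step is a 1.3-fold lower number from compound 2 to compound 4 (0.10 log units; within the scatter) even though 2-(trifluoromethyl)pyridin-4-yl brings 10 heavy atoms where methoxy had 2. The comparisons with the other two compounds agree, with a 1.0-fold higher number from compound 3 to compound 4 (0.01 log units; within the scatter) and a 1.6-fold higher number from compound 1 to compound 4 (0.20 log units; within the scatter) so that hydrogen, chloro, methoxy and this much larger group cannot be told apart here. Nothing available accounts for this tolerance.

The compounds shown leave open whether an amine or a carboxylic acid at this aromatic carbon, or a longer chain ending in such a group, would move the number beyond the scatter. They also leave open whether a plain phenyl ring, without the ring nitrogen or the trifluoromethyl, would match compound 4.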